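Trimming the Arylthio Arm: From Compound 1 to Compound 4

The source may hold more compounds than are shown below. What is called first, only, known or untested is meant among the compounds shown, and "the series" means these compounds.

Three analogues sharing one core have been tested in a functional assay on MCF7 cells (Homo sapiens) for inhibition, read by MTT assay, with a stated time of 72 h; a higher number here means a weaker inhibitor, a lower number a stronger inhibitor. Compound 1 `Cc1cc(Nc2cc(-c3ccccc3)[nH]n2)n2nc(SCc3ccc([N+](=O)[O-])cc3)nc2n1` gives 5060 nM in this assay, the highest of the three numbers, yet within the usual scatter of both neighbours. Compound 2 `Cc1cc(Nc2cc(-c3ccc(Cl)cc3)[nH]n2)n2nc(SCc3ccc(Br)cc3)nc2n1` gives 3620 nM in this assay, and compound 3 `Cc1cc(Nc2ccn(Cc3csc4ccc(Cl)cc34)n2)n2nc(SCc3ccc(Br)cc3)nc2n1` gives 2570 nM in this assay, so no ordering among the three can be drawn.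

Compound 4 `CCCSc1nc2nc(C)cc(Nc3cc(-c4ccccc4)[nH]n3)n2n1` is not yet measured. It differs from compound 1 in one place: ethyl in place of 4-nitrophenyl on a saturated chain carbon bound to a sulfur. The change removes the whole aromatic portion of the arm attached to the sulfur and leaves a short saturated chain in its place.

For the measured compounds named here, nothing among the measured compounds probes this kind of change, since all three carry an aryl group on that arm. The author therefore expects at most a modest step for compound 4, of size a 1.5-fold higher number from compound 1 to compound 4 (0.17 log units; within the scatter), leaning toward a weaker inhibitor but possibly no change beyond the scatter. Compound 4 is estimated at 7500 nM, within a range from 2500 nM to 22000 nM.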

Compound 4, half-maximal inhibitory concentration: > 50000 nM
Compound 4 ended at the assay's limit; the forecaster's own chance of this, stated with the estimate: 15%; middle value at least 6.6-fold (0.82 log units) away from the limit.
By their numbers in this assay, from the lowest: compounds 3, 2 and 1 (each within the scatter of the next). At a limit, above all of these: compound 4.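

Compound 4 reads > 50000 nM in this assay, and this is a limit of the assay, not a number. For the compounds shown here, putting ethyl in place of 4-nitrophenyl on a saturated chain carbon bound to a sulfur gives an at least 9.8-fold higher number from compound 1 to compound 4 (0.99 log units; beyond the scatter), so this arm, aryl-bearing in all the earlier compounds and never varied alone among them, proves able to carry a large change in this read-out. The full size of the step cannot be read because the result ends at a limit: the limit of > 50000 nM in this assay, at which 1 of the 4 values shown sits.

Going by these compounds, whether a plain benzyl group, a longer chain such as hexyl, or a chain ending in an amine would keep the value of compound 1 stays open. Also open, on these data alone, is whether a propyl arm on the sulfur would have the same effect in the settings of compound 2 and compound 3.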